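The source may report more compounds than this note shows. Statements on the series, on what has been measured and on what is new or still open speak of the compounds shown alone.

Measured in a functional assay on HCT-116 cells (Homo sapiens) for cytotoxicity, read by fluorescence, with a stated time of 72 h; a lower number here means a stronger inhibitor, a higher number a weaker inhibitor:
- compound 1 `CC(C)c1n[nH]c2c(NCc3ccc(-c4ccccn4)cc3)nc(NCC(C)(C)O)nc12`: 85 nM
- compound 2 `CC(C)c1n[nH]c2c(NCc3ccc(-c4ccccn4)cc3)nc(N3CCCCC3CCO)nc12`: 142 nM

Only these two compounds have been measured so far, and compound 1 stands within the scatter of compound 2. The next compound, compound 3 `CC(C)c1n[nH]c2c(NCc3ccc(-c4ccccn4)cc3)nc(N[C@H]3CC[C@H](N)CC3)nc12`, keeps the core of compound 1 and changes one side group. 4-aminocyclohexyl in place of 2-hydroxy-2-methylpropyl on a nitrogen on an aromatic ring In words, 4-aminocyclohexyl takes the place of 2-hydroxy-2-methylpropyl on a nitrogen on an aromatic ring.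

Among the compounds with values here, one measured step bears on this change. In it, 2-(2-hydroxyethyl)piperidin-1-yl replaces the same (2-hydroxy-2-methylpropyl)amino group, and the result is a 1.7-fold higher number from compound 1 to compound 2 (0.22 log units; within the scatter). Within the data shown here, that replacement is a different one, and no measured compound carries 4-aminocyclohexyl, so the evidence is thin. On this single step, no change beyond the scatter is expected in this assay, with only a slight and unproven lean towards a lower number.

For compound 3 the expected value is 60 nM, with an estimated range of 20 nM to 180 nM. The expected step is a 1.4-fold lower number from compound 1 to compound 3 (0.15 log units; within the scatter).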

Compound 3, half-maximal inhibitory concentration: 720 nM
For compound 3 the middle estimate is 12-fold (1.08 log units) below the measured one, and the stated range ends below it.
By their numbers in this assay, from the lowest: compounds 1 and 2 (each within the scatter of the next); then compound 3.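

In this assay, this place on the shared core had so far shown no change beyond the scatter, but (4-aminocyclohexyl)amino moves the number clearly, with an 8.5-fold higher number from compound 1 to compound 3 (0.93 log units; beyond the scatter) and a 5.1-fold higher number from compound 2 to compound 3 (0.71 log units; beyond the scatter). The position is therefore not indifferent to the group it carries, and a ring in this group does not by itself go with the higher number, since compound 2 also carries a ring here, in its 2-(2-hydroxyethyl)piperidin-1-yl group, and stands within the scatter of compound 1. Nothing measured here accounts for the rise in the number on moving to 4-aminocyclohexyl.

The compounds shown leave open whether the higher number goes with the amine or with the cyclohexyl ring that carries it, a question that a 4-hydroxycyclohexyl group at the same place would bear on. They also leave open whether the two defined stereocentres of 4-aminocyclohexyl matter, as the other arrangement of the amine on that ring does not appear among them.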